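The source may report more compounds than this note shows. Statements on the series, on what has been measured and on what is new or still open speak of the compounds shown alone.

Measured so far in an ADME assay on L929 cells (Mus musculus) for cytotoxicity, read by resazurin assay, with a stated time of 72 h; a higher number here means a weaker inhibitor, a lower number a stronger inhibitor:

- compound 1, `Cc1ccc(C(=O)/C=C/c2ccc3c(c2)B(O)OC3)cc1`, gives > 10 ug/mL; this is a limit of the assay, not a number.
- compound 2, `CSc1ccc(C(=O)/C=C/c2ccc3c(c2)B(O)OC3)cc1`, gives > 10 ug/mL; again a limit.
- compound 3, `CCc1ccc(C(=O)/C=C/c2ccc3c(c2)B(O)OC3)cc1`, gives > 10 ug/mL; again a limit.

Compound 1 therefore stands nowhere exact on the scale: only a limit is known for it, and every value in the set sits at the limit of > 10 ug/mL in this assay, at which 3 of the 3 values shown sit. The steps between the measured compounds, a step that the two limits leave unreadable from compound 1 to compound 2, a step that the two limits leave unreadable from compound 1 to compound 3 and a step that the two limits leave unreadable from compound 2 to compound 3, are each unreadable, since both ends are limits.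

The next compound is compound 4, `O=C(/C=C/c1ccc2c(c1)B(O)OC2)c1ccccn1`. Its difference from compound 1 is pyridin-2-yl in place of 4-methylphenyl on a carbonyl carbon. Within the data shown here, none of the measured steps touches this position in the same way; each of them varies the substituent on the ring that leaves here, and none exchanges the ring itself. Among the measured compounds shown here, no readable step therefore bears on the change, and the only guidance is that every measured member of the series sits at the limit.

On that basis compound 4 is expected to remain at or near the limit, with an estimated value of 20 ug/mL. The estimate for compound 4 spans 8 ug/mL to 60 ug/mL. The step this estimate means is a step that the limit leaves unreadable from compound 1 to compound 4, expected to be no larger than the scatter.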

Compound 4, half-maximal inhibitory concentration: > 10 ug/mL
Compound 4 was reported as a limit; the forecaster's own chance of this, stated with the estimate: 80%; the middle value lies beyond the limit too.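

In this assay compound 4 gives > 10 ug/mL, which is a limit and not a number. No new step can be read from compound 1 to compound 4, since both ends are limits. The series sits at one value: the limit of > 10 ug/mL in this assay, at which 4 of the 4 values shown sit.

The compounds shown leave open where any of them lies on the scale, and whether any change in the series shifts the value.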